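A few compounds are considered here, and "the series" means these few. Any claim that something is new, unique, unknown or untested is made for them only; others in the source may bear on it.

The set is judged in a functional assay on NUGC-3 cells (Homo sapiens) for inhibition, read by sulforhodamine B assay, with a stated time of 48 h; a lower number here means a stronger inhibitor of growth, a higher number a weaker inhibitor of growth. Compound 1 `O=C(Nc1ccc(C(F)(F)F)cc1)C1NCCc2ccccc21` gives 4220 nM in this assay. Compound 2 `COc1ccccc1NC(=O)C1c2ccccc2CCN1C(=O)c1ccc(Cl)cc1`, which carries a further amide on the ring nitrogen of its core, gives 1590 nM in this assay. Compound 3 `COc1cccc(NC(=O)c2nccc3ccccc23)c1`, built on a different core, gives > 10000 nM in this assay, and this reading is a limit of the assay rather than a number. Among the three values shown, compound 3 is therefore the one that sits at the limit of > 10000 nM in this assay, at which 1 of the 3 values shown sits, so where it truly stands beyond that limit cannot be said from the data.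

Compound 4 `O=C(Nc1cccc(Cl)c1)c1nccc2ccccc12` is the next compound, not yet measured in this assay. It differs from compound 3 in one place: chloro in place of methoxy on an aromatic carbon. For the measured compounds named here, no pair of measured compounds that differ in a single place is available, so the size of such a change cannot be read from a measured step. The expectation is that compound 4 stays a weak inhibitor of growth, with the step of an at least 1.2-fold lower number from compound 3 to compound 4 (0.09 log units; that floor lies within the scatter) expected to be small and possibly none beyond the usual scatter, and a fair chance that the assay again reports only a limit. Compound 4 is estimated at 8000 nM in this assay, in a range from 2500 nM to 30000 nM.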

Compound 4, concentration for 50% growth inhibition: > 10000 nM
Compound 4 ended at the assay's limit (the forecaster's own chance of this, stated with the estimate: 45%); at least 1.2-fold (0.09 log units) between middle value and limit.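

Compound 3 and compound 4 both end at a limit of the assay rather than at a number, so no step can be read between them: the limit of > 10000 nM in this assay, at which 2 of the 4 values shown sit.

The compounds shown leave open how far chloro and methoxy truly differ in this assay, and whether any change to the core of compound 3 yields a readable value.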